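Cyclopropyl in Place of Methyl: Expectation for Compound 4

The compounds below may be only part of what the source reports. "The series", "measured", "known", "first", "only" and "open" are said of these compounds alone.

Of the compounds shown here, three share one core and have been tested in an assay for inhibition of high affinity nerve growth factor receptor (Homo sapiens), read by HTRF, with a stated time of 30 min, in the presence of a further agent that is not named here; a lower number here means a stronger inhibitor, a higher number a weaker inhibitor. Compound 1 `Fc1ccc(CNc2nc(Nc3cc(C4CC4)[nH]n3)c3cc(F)ccc3n2)c(F)c1` gives 59 nM, and compound 2 `Fc1ccc(CNc2nc(Nc3cc(C4CC4)[nH]n3)c3cc(Cl)ccc3n2)c(F)c1` gives 72 nM; the step of a 1.2-fold higher number from compound 1 to compound 2 (0.09 log units; within the scatter) lies within the scatter. Compound 3 `Cc1ccc2nc(NCc3ccc(F)cc3F)nc(Nc3cc(C)[nH]n3)c2c1` gives 110 nM, a number within the scatter of both compound 2 and compound 1. Compound 4 `Cc1ccc2nc(NCc3ccc(F)cc3F)nc(Nc3cc(C4CC4)[nH]n3)c2c1` differs from compound 3 by cyclopropyl in place of methyl on an aromatic carbon, on an aromatic carbon of a five-membered aromatic ring with 2 nitrogen, next to the ring nitrogen. Going by the values given here, no measured step isolates this change, since compound 3 differs from compounds 1 and 2 in two places, so the expected step of a 1.5-fold lower number from compound 3 to compound 4 (0.17 log units; within the scatter) is small. Compound 4 is estimated at 75 nM, with a range from 30 nM to 180 nM.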

Compound 4, half-maximal inhibitory concentration: 57 nM
For compound 4 the middle estimate is 1.3-fold (0.12 log units) above the measured one, and the stated range covers the measured number.
By their numbers in this assay, from the lowest: compounds 4, 1, 2 and 3 (each within the scatter of the next).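

In this assay, going by these compounds alone, compound 4 gives the first direct reading of 5-methyl-1H-pyrazol-3-yl changing to 5-cyclopropyl-1H-pyrazol-3-yl, with a 1.9-fold lower number from compound 3 to compound 4 (0.29 log units; within the scatter), so the two groups cannot be told apart here. With cyclopropyl held in place, methyl, chloro and fluoro on the core cannot be told apart either, with a 1.3-fold lower number from compound 2 to compound 4 (0.10 log units; within the scatter) and a 1.0-fold lower number from compound 1 to compound 4 (0.01 log units; within the scatter). No available evidence bears on why these numbers fall as they do. From the compounds shown here alone, whether a tert-butyl, a phenyl or an amine in place of cyclopropyl would give a step beyond the scatter remains open.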